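Chain Length and Growth Inhibition in a Hydroxamate Series

The compounds below may be only part of what the source reports. "The series", "measured", "known", "first", "only" and "open" are said of these compounds alone.

Measured compounds:
compound 1 `CC(C)CCc1c(OCCCCCCC(=O)NO)ccc2c1OC(=O)CC2` — > 30000 nM
compound 2 `CC(C)CCc1c(OCCCCC(=O)NO)ccc(CCC(=O)NO)c1O` — 14100 nM
compound 3 `CC(C)CCc1c(OCCCCCC(=O)NO)ccc2c1OC(=O)CC2` — > 30000 nM

In a functional assay on Hep 3B2 cells (Homo sapiens) for antiproliferative activity, read by sulforhodamine B assay, with a stated time of 48 h (on this read-out higher numbers stand for weaker inhibition of growth and lower numbers for stronger inhibition of growth), compound 1 reaches only a limit, > 30000 nM. Compound 3 likewise reaches only a limit, > 30000 nM. The change between them is (hydroxycarbamoyl)methyl in place of hydroxycarbamoyl on a saturated chain carbon, five bonds along the chain from an oxygen on an aromatic ring, and its step that the two limits leave unreadable from compound 3 to compound 1 cannot be sized because both values sit at the limit (the limit of > 30000 nM in this assay, at which 2 of the 3 values shown sit). Compound 2 gives a number, 14100 nM; how its core differs from that of compound 3 is not broken down here. Compound 4 `CC(C)CCc1c(OCCCCCC(=O)NO)ccc(CCC(=O)NO)c1O` carries the same kind of change, ((hydroxycarbamoyl)methyl in place of hydroxycarbamoyl on a saturated chain carbon, four bonds along the chain from an oxygen on an aromatic ring), though the place differs: four bonds along the chain from an oxygen on an aromatic ring rather than five. For the measured compounds named here, since the only measured instance of this change is unreadable, compound 4 is expected to stay close to compound 2 with a step of a 1.0-fold lower number from compound 2 to compound 4 (0.00 log units; within the scatter), estimated at 14000 nM within 6000 nM to 30000 nM.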

Compound 4, concentration for 50% growth inhibition: 1980 nM
The estimate for compound 4 lay 7.1-fold (0.85 log units) above the measured number, and the stated range ends above it.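

In this assay, (hydroxycarbamoyl)methyl in place of hydroxycarbamoyl gives a 7.1-fold lower number from compound 2 to compound 4 (0.85 log units; beyond the scatter), so on this core the longer chain goes with stronger inhibition of growth. This is a single pair on a single core, and it shows no general rule for the series. The same change on the core of compound 3 gives a step that cannot be read, so the compounds show neither that this gain carries over from one core to the other nor that it fails to: the limit of > 30000 nM in this assay, at which 2 of the 4 values shown sit.

From the compounds shown here alone, it remains open whether a longer chain, such as 3-(hydroxycarbamoyl)propyl or 4-(hydroxycarbamoyl)butyl, would lower the number further on the core of compound 4. Also open, going by these compounds, is how a carboxylic acid in place of hydroxycarbamoyl would read on that core.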